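This account rests on a few compounds, and the source may have more. Where it says the series, first, only, none or still open, it means among the compounds named here.

Measured compounds:
Compound 1 `Cc1c(C#N)ccnc1O[C@@H]1CC[C@@H](C)N(C(=O)c2ccccc2C(F)(F)F)C1` gives 21 nM in a functional assay on cells for antagonist activity at Orexin receptor type 2 (Homo sapiens), read by FLIPR and calcium flux; a higher number here means a weaker inhibitor, a lower number a stronger inhibitor.
Compound 2 `CCOc1ccccc1C(=O)N1C[C@H](Oc2nccc(C#N)c2C)CC[C@H]1C` gives 6 nM in this assay.

Going by the values given here, of the two numbers, compound 2 has the lower one; the only comparison is the step of a 3.5-fold lower number from compound 1 to compound 2 (0.54 log units; beyond the scatter), in which the trifluoromethyl on the benzamide ring of the shared core was exchanged for ethoxy. Compound 3 `Cc1c(C#N)ccnc1O[C@@H]1CC[C@@H](C)N(C(=O)c2ccccc2-n2ncnn2)C1` keeps the core of compound 2 and alters that same position: 2H-tetrazol-2-yl in place of ethoxy on an aromatic carbon. Among the compounds with values here, the single measured step bears on it only loosely, since it shows that the group at this position matters and that exchanging one for another moves the half-maximal inhibitory concentration by a modest amount, without telling in which direction a third, larger ring-bearing group will go. The expected step of a 1.7-fold higher number from compound 2 to compound 3 (0.22 log units; within the scatter) is therefore a small one, with compound 3 likely to land between the two measured values or near them. The estimate for compound 3 in this assay is 10 nM, within a range of 3 nM to 40 nM.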

Compound 3, half-maximal inhibitory concentration: 7.7 nM
The estimate for compound 3 lay 1.3-fold (0.11 log units) above the measured number; measured number inside the range.
By their numbers in this assay, from the lowest: compounds 2 and 3 (each within the scatter of the next); then compound 1.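

In this assay, the step of a 1.3-fold higher number from compound 2 to compound 3 (0.11 log units; within the scatter) shows that this position, on an aromatic carbon ortho to a large group, can carry 2H-tetrazol-2-yl, a five-membered aromatic ring, as well as the open ethoxy chain, with no difference beyond the scatter between the two. The step of a 2.7-fold lower number from compound 1 to compound 3 (0.44 log units; beyond the scatter) adds a second group that stands apart from trifluoromethyl by more than the scatter, so the advantage over compound 1 seen with ethoxy is no longer tied to that one group and is shared by two quite different substituents. No measurement of any underlying property accompanies these numbers, so nothing here accounts for the trifluoromethyl compound's higher number or for the match between ethoxy and the tetrazole.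

Going by these compounds, whether an amine, a carboxylic acid, a longer alkoxy chain such as butoxy or a six-membered ring such as pyridine at this position would stay in the range of compound 2 and compound 3 remains open. Only this one position varies among the compounds shown, so it is also open whether the same ranking of groups would hold if the nitrile or the methyl on the core were exchanged.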